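Half-life series: chloro to fluoro swap on the shared core

A few compounds are considered here, and "the series" means these few. Any claim that something is new, unique, unknown or untested is made for them only; others in the source may bear on it.

Among the measured compounds shown here, compound 1 `Clc1ccc(C2(Cn3cncn3)COC(c3cc4ccc(Cl)cc4s3)=N2)cc1` has the higher of the two numbers so far: in an ADME assay on microsomes from liver (Homo sapiens) for metabolic stability, read by LC-MS, using NADPH, with stated times of 10 min and 60 min, tested at 100 uM (a higher number here means that the compound lasts longer, a lower number that the compound disappears faster), compound 1 gives 1.16 h, while compound 2 `Fc1ccc(C2(Cn3cncn3)COC(c3ccc(-c4ccoc4)cc3)=N2)cc1` in this assay gives 0.31 h, a gap beyond the scatter. Compound 3 `Fc1ccc(C2(Cn3cncn3)COC(c3cc4ccc(Cl)cc4s3)=N2)cc1` is not yet measured. It differs from compound 1 in one place (fluoro in place of chloro on an aromatic carbon). For the measured compounds named here, no measured pair isolates this change, so the expected step from compound 1 to compound 3 in this assay is small and downward, likely within the scatter, a 1.5-fold lower number from compound 1 to compound 3 (0.16 log units; within the scatter). Compound 3 is therefore estimated at 0.8 h, within 0.4 h to 1.6 h.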

Compound 3, half-life: 1.34 h
Compound 3: the middle estimate sits 1.7-fold (0.22 log units) below what was measured; measured number inside the range.
By their numbers in this assay, from the lowest: compound 2; then compounds 1 and 3 (each within the scatter of the next).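

On the six-membered aromatic ring of carbon only, para to a large group, 4-chlorophenyl to 4-fluorophenyl gives a 1.2-fold higher number from compound 1 to compound 3 (0.06 log units; within the scatter) in this assay. Among the compounds shown here, this is the first measured pair to isolate this change, and with the rest of the structure held constant, the half-life does not separate chloro from fluoro at this position. Nothing available here bears on the reason for this result.

Still open, going by these compounds, is how a methoxy group, an amine or a trifluoromethyl group on this carbon would read in this assay. Also open, on these data alone, is whether the same swap reads alike when the other substituent on the shared core is different.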